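The compounds below may be only part of what the source reports. "The series", "measured", "known", "first", "only" and "open" are said of these compounds alone.

Measured compounds:
compound 1 `CC1=CC[C@H]2[C@H](CC[C@]2(C)O)C(C)(C)[C@@H]1CC[C@H]1[C@]2(C)CC[C@H](OC(=O)c3ccccc3)C(C)(C)O[C@H]2CC[C@@]1(C)O`: 16100 nM
compound 2 `CC1=CC[C@H]2[C@H](CC[C@]2(C)O)C(C)(C)[C@@H]1CC[C@H]1[C@]2(C)CC/C(=N/OC(=O)c3ccccc3)C(C)(C)O[C@H]2CC[C@@]1(C)O`: 27400 nM

Both numbers come from a functional assay on MDA-MB-231 cells (Homo sapiens) for antiproliferative activity, read by MTT assay, with a stated time of 72 h; on this read-out higher numbers stand for weaker inhibition and lower numbers for stronger inhibition. Compound 1 gives 16100 nM, and compound 2 gives 27400 nM; the gap between the two lies within the usual scatter of repeated measurements, so the two compounds cannot be told apart on these numbers, and neither counts as the more active one. Among the measured compounds shown here, no pair of measured compounds differs in only one place, so no measured step is available to lean on.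

Compound 3 `COc1ccc(C(=O)O[C@H]2CC[C@]3(C)[C@H](CC[C@@](C)(O)[C@H]3CC[C@@H]3C(C)=CC[C@H]4[C@H](CC[C@]4(C)O)C3(C)C)OC2(C)C)cc1` is not yet measured. It differs from compound 1 by a single change: methoxy in place of hydrogen on an aromatic carbon. For the measured compounds named here, nothing among the measured compounds shows what this change does in this assay, so the expectation rests on the shared core, which compound 1 already carries at a weakly inhibiting level. The step from compound 1 to compound 3 is expected to be small and of no certain direction, a 1.1-fold lower number from compound 1 to compound 3 (0.03 log units; within the scatter), within the scatter. Compound 3 is therefore estimated at 15000 nM, with a range from 5000 nM to 45000 nM.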

Compound 3, half-maximal inhibitory concentration: 30600 nM
Compound 3: middle estimate off by 2.0-fold (0.31 log units), on the low side; measured number inside the range.
By their numbers in this assay, from the lowest: compounds 1, 2 and 3 (each within the scatter of the next).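

In this assay, among the compounds shown here, swapping benzoyl for (4-methoxyphenyl)carbonyl gives a 1.9-fold higher number from compound 1 to compound 3 (0.28 log units; within the scatter), the first measured step in this set that isolates a single place on these molecules. At this aromatic carbon, para to a large group, methoxy in place of hydrogen therefore makes no difference that can be separated from the ordinary spread of repeated measurements, and compound 3, at 30600 nM, cannot be told apart from compound 1 on these numbers. For the compounds shown here, the step shows only that this one group at this one carbon leaves the read-out within that spread, and no separate measurement is available to explain the result.

On these data alone, one group at one carbon cannot reveal how sensitive this position is in general, so it remains open whether an amine, a carboxylic acid or a longer chain such as butoxy at the same carbon would produce a step beyond the scatter. As far as these compounds go, it also remains open whether methoxy on a different carbon of the same aromatic ring would behave as it does here, or whether replacing the whole ring would matter more than decorating it.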